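Stilbene ether amines in the maximal electroshock model

The source may report more compounds than this note shows. Statements on the series, on what has been measured and on what is new or still open speak of the compounds shown alone.

Measured so far:
compound 1 `CN(C)CCCCOc1ccccc1/C=C/c1cccc(Cl)c1`: 14.3%
compound 2 `CN(C)CCCCOc1ccccc1/C=C/c1ccc(Cl)cc1`: 0%
compound 3 `CCCN(CCC)CCCCOc1ccccc1/C=C/c1ccccc1`: 0%

In a functional assay on the whole organism with Mus musculus as the target, in the maximal electroshock model, at a dose of 50 mg/kg by the oral route (on this read-out higher numbers stand for more inhibition at the one dose given (going by the name of the read-out) and lower numbers for less inhibition), compound 3 gives 0%. On this read-out compound 3 stands level with compound 2 at the digits printed, and together these two are the lowest of the three numbers; compound 1, the furthest from compound 3, sits higher by an amount beyond the scatter.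

Compound 4 `OC1CCN(CCCCOc2ccccc2/C=C/c2ccccc2)CC1` is not yet measured. Its difference from compound 3: 4-hydroxypiperidin-1-yl in place of dipropylamino on a saturated chain carbon, four bonds along the chain from an oxygen on an aromatic ring.

Within the data shown here, the only step measured is a number 14.3 percentage points lower from compound 1 to compound 2 (beyond the scatter), which concerns the chlorophenyl ring, not the amine end of the chain. Among the measured compounds shown here, no measured step touches the amine, so there is nothing in the numbers that predicts the effect of exchanging dipropylamino for 4-hydroxypiperidin-1-yl. With compound 3 at the floor of the read-out, the default expectation is a step of a number 8 percentage points higher from compound 3 to compound 4 (within the scatter) in this assay, no larger than the scatter.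

Compound 4 is therefore estimated at 8% in this assay, with a range of 0% to 28%.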

Compound 4, a percentage reported as inhibition, in the whole organism at one dose (the size of the read-out at that dose, not a potency): 0%
Compound 4: middle estimate off by 8 percentage points, on the high side; measured number inside the range.
By their numbers in this assay, from the lowest: compounds 2, 3 and 4 (each within the scatter of the next); then compound 1.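

In this assay, exchanging dipropylamino for 4-hydroxypiperidin-1-yl on a saturated chain carbon, four bonds along the chain from an oxygen on an aromatic ring, gives no change at the digits printed from compound 3 to compound 4 (within the scatter). Among these compounds, this is the first measured step at the amine end of the chain: an open-chain amine and a six-membered non-aromatic ring bearing a hydroxyl read alike, both at the floor of the scale, so any difference between them stays hidden in either direction. Nothing available bears on why the two read alike.

From the compounds shown here alone, whether a morpholin-4-yl or a piperazin-1-yl at this chain end would lift the number off the floor remains open. Also open, going by these compounds, is how 4-hydroxypiperidin-1-yl reads when paired with the 3-chlorophenyl of compound 1, which gives 14.3%.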